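A few compounds are considered here, and "the series" means these few. Any claim that something is new, unique, unknown or untested is made for them only; others in the source may bear on it.

Of the compounds shown here, three have been measured so far in a toxicity assay on THP-1 cells (Homo sapiens) for inhibition (a higher number here means that more compound is tolerated, a lower number that less compound is tolerated), and each gives only a limit rather than a number. Compound 1 `Cc1ccccc1C(=O)Nc1ncc(-c2ccccc2)n1C` gives > 100000 nM, which is a limit. Compound 2 `Cc1cccc(C(=O)Nc2ncc(-c3ccccc3)n2C)c1` gives > 50000 nM, also a limit, and this is all that is known about where it stands. Compound 3 `COc1ccc(-c2ccc(NC(=O)c3ccc(F)cc3)nc2)cc1`, which has a different core, gives > 100000 nM, again a limit.

Compound 4 `Cc1ccc(C(=O)Nc2ncc(-c3ccccc3)n2C)cc1` has not yet been measured. It has the same atoms as compound 2, joined differently, with 4-methylphenyl in place of 3-methylphenyl on a carbonyl carbon.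

For the measured compounds named here, only one measured step bears on this change. Going by a step that the two limits leave unreadable from compound 1 to compound 2, a swap of the same kind on the same carbonyl carbon whose size cannot be read, no step beyond the usual scatter is expected in this assay, in either direction. The anchor for this expectation is compound 2 at > 50000 nM, a limit. The expected size is a step that the limit leaves unreadable from compound 2 to compound 4, and this is an estimate only. A reported limit is also likely in place of a number. For compound 4 the estimated value is 80000 nM, with an expected range from 40000 nM to 150000 nM.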

Compound 4, half-maximal cytotoxic concentration: > 50000 nM
Compound 4 gave a limit, no number; the forecaster's own chance of this, stated with the estimate: 85%; the middle value does not contradict the limit.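

In this assay, no step can be read among compound 1, compound 2 and compound 4, because each gives a limit rather than a number: the limit of > 50000 nM in this assay, at which 2 of the 4 values shown sit.

The compounds shown leave open whether 2-methylphenyl, 3-methylphenyl and 4-methylphenyl differ at all in this read-out, and what the half-maximal cytotoxic concentration of each compound actually is.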